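The compounds below may be only part of what the source reports. "The series", "measured", "known", "first", "only" and "open" are said of these compounds alone.

Four compounds sharing one core are at issue here, all carrying an amine-bearing chain on an oxygen of that core. In a functional assay on A549 cells (Homo sapiens) for cytotoxicity, read by MTT assay, with a stated time of 48 h (on this read-out higher numbers stand for weaker inhibition and lower numbers for stronger inhibition), compound 1 `CN1CCN(CCCCOc2c(O)cc(O)c3c(=O)cc(-c4ccccc4)oc23)CC1` gives > 100000 nM, which is a limit of the assay and not a number. Compound 2 `CC(CO)NCCOc1c(O)cc(O)c2c(=O)cc(-c3ccccc3)oc12` has the entry "not determined" (no result reported). Compound 3 `CCCNCCCCOc1c(O)cc(O)c2c(=O)cc(-c3ccccc3)oc12` likewise has the entry "not determined" (no result reported), so it holds no place on the scale of this assay. The only reference point in the series is therefore (the limit of > 100000 nM in this assay, at which 1 of the 3 values shown sits).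

The next compound to be tested is compound 4 `CN(C)CCCOc1c(O)cc(O)c2c(=O)cc(-c3ccccc3)oc12`. Its structural change is dimethylamino in place of (propylamino)methyl on a saturated chain carbon, three bonds along the chain from an oxygen on an aromatic ring. With no number for compound 3, the size of this step cannot be read from the data, and any expectation has to lean on its one measured relative. Compound 1 offers only its limit of > 100000 nM as a guide. On that basis, at most a modest move toward stronger inhibition is expected in this assay, and a result that is again only a limit would be no surprise. For compound 4 the estimated value is 50000 nM, with an expected range from 15000 nM to 100000 nM.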

Compound 4, half-maximal inhibitory concentration: > 100000 nM
Compound 4 was reported as a limit; the forecaster's own chance of this, stated with the estimate: 45%; middle value at least 2.0-fold (0.30 log units) from the limit.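

In this assay compound 4 gives > 100000 nM, which is a limit of the assay and not a number. Among the compounds shown here, compound 1 stands at a limit too, so no step from compound 1 or compound 3 to compound 4 can be read. Whether any amine-bearing chain shown here gives a measurable value in this read-out stays open: the limit of > 100000 nM in this assay, at which 2 of the 4 values shown sit.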